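Methyl addition on the aryl ring of compound 2

This account rests on a few compounds, and the source may have more. Where it says the series, first, only, none or still open, it means among the compounds named here.

Compound 1 `CCC1=C(O)c2c(oc(-c3ccc(OC)cc3C)cc2=O)C(CC)(CC)C1=O`: 20.9 uM
Compound 2 `CCC1=C(O)c2c(oc(-c3ccc(OC)c(C)c3)cc2=O)C(CC)(CC)C1=O`: 28.5 uM

Both values come from a functional assay on KB cells (Homo sapiens) for antiproliferative activity, read by sulforhodamine B assay, with a stated time of 3 days; on this read-out higher numbers stand for an effect only at larger amounts of compound and lower numbers for an effect already at smaller amounts. Within the data shown here, compound 2, at 28.5 uM, cannot be separated from compound 1, the only other measured member of the series: a 1.4-fold higher number from compound 1 to compound 2 (0.13 log units; within the scatter).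

The next compound is compound 3 `CCC1=C(O)c2c(oc(-c3cc(C)c(OC)cc3C)cc2=O)C(CC)(CC)C1=O`. The change is methyl in place of hydrogen on an aromatic carbon, ortho to a large group, meta to a methoxy group and para to a methyl group.

Among the measured compounds shown here, only one measured step bears on this change, a 1.4-fold higher number from compound 1 to compound 2 (0.13 log units; within the scatter). For the measured compounds named here, it involves a methyl group on the same aromatic ring, but no measured step adds a methyl group to that ring, so the evidence is indirect. That single small step gives no reason to expect a shift beyond the scatter in this assay, and no direction can be argued with confidence. The expected step is a 1.2-fold lower number from compound 2 to compound 3 (0.07 log units; within the scatter). Compound 3 is estimated at 24 uM, with an expected range of 11 uM to 50 uM.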

Compound 3, concentration for half-maximal effect: 36.6 uM
Beside the measured number, compound 3's estimate is 1.5-fold (0.18 log units) below it; low and high end bracket the measured number.
By their numbers in this assay, from the lowest: compounds 1, 2 and 3 (each within the scatter of the next).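

In this assay, methyl in place of hydrogen, ortho to a large group, meta to a methoxy group and para to a methyl group, gives a 1.3-fold higher number from compound 2 to compound 3 (0.11 log units; within the scatter). Among these compounds, this is the first measured step that adds a methyl group to this aromatic ring, rather than showing one methyl group in two different places. The other addition ending in compound 3, also methyl in place of hydrogen on an aromatic carbon, gives a 1.8-fold higher number from compound 1 to compound 3 (0.24 log units; within the scatter), so with both steps within the scatter, compound 3, which carries both methyl groups, cannot be separated from either compound with one methyl group in this assay, and nothing measured here offers an explanation for either step.

On these data alone, whether a different group on this aromatic carbon, such as an amine, a carboxylic acid or a longer chain, would give a step beyond the scatter remains open. Also open, as far as these compounds go, is how a compound with hydrogen at both methyl-bearing places on the ring would compare with compound 1, compound 2 and compound 3 in this assay.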